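Series notes: from compound 2 to compound 3

A few compounds are considered here, and "the series" means these few. Any claim that something is new, unique, unknown or untested is made for them only; others in the source may bear on it.

Measured so far in a physicochemical assay for solubility, in phosphate buffer, at pH 6.5; a higher number here means a more soluble compound, a lower number a less soluble compound
- compound 1 `C=C[C@@H]1C[C@]1(NC(=O)[C@@H]1C[C@@H](Oc2nccc3cc(OC)ccc23)CN1C(=O)[C@@H](NC(=O)N[C@H](COC)C(C)(C)C)C(C)(C)C)C(=O)NS(=O)(=O)C1CC1` gives 609 ug/mL
- compound 2 `C=C[C@@H]1C[C@]1(NC(=O)[C@@H]1C[C@@H](Oc2nccc3cc(OC)ccc23)CN1C(=O)[C@@H](NC(=O)N[C@H](COC)c1ccccc1)C(C)(C)C)C(=O)NS(=O)(=O)C1CC1` gives 259 ug/mL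

Within the data shown here, compound 2 stands lowest of the two numbers so far. Unmeasured compound 3 `C=C[C@@H]1C[C@]1(NC(=O)[C@@H]1C[C@@H](Oc2nccc3cc(OC)ccc23)CN1C(=O)[C@@H](NC(=O)N[C@H](C(=O)OC)C(C)(C)C)C(C)(C)C)C(=O)NS(=O)(=O)C1CC1` has 1-(methoxycarbonyl)-2,2-dimethylpropyl in place of 2-methoxy-1-phenylethyl on an amide-type nitrogen and so loses the aromatic ring. Among the measured compounds shown here, one measured step bears on this: a 2.4-fold lower number from compound 1 to compound 2 (0.37 log units; beyond the scatter) with phenyl in place of tert-butyl, modest and beyond the scatter. Here the phenyl leaves, so a step of similar size in the opposite direction is expected, although no measured step covers methoxycarbonyl. The expected change is a 1.9-fold higher number from compound 2 to compound 3 (0.27 log units; within the scatter) towards a higher number. Compound 3 is estimated at 480 ug/mL with an expected range of 220 ug/mL to 1000 ug/mL in this measurement.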

Compound 3, solubility: 754 ug/mL
For compound 3 the middle estimate is 1.6-fold (0.20 log units) below the measured one; measured number inside the range.
By their numbers in this assay, from the lowest: compound 2; then compounds 1 and 3 (each within the scatter of the next).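

In this assay, 1-(methoxycarbonyl)-2,2-dimethylpropyl in place of 2-methoxy-1-phenylethyl on the amide-type nitrogen gives a 2.9-fold higher number from compound 2 to compound 3 (0.46 log units; beyond the scatter), which leaves compound 2 set apart from both other compounds. With the tert-butyl kept, methoxycarbonyl in place of methoxymethyl gives a 1.2-fold higher number from compound 1 to compound 3 (0.09 log units; within the scatter), so these two groups cannot be told apart at this position in this read-out, and of the changes shown only the one involving the phenyl gives a step beyond the scatter. No measurement shown here accounts for either step.

Open, going by these compounds, is whether phenyl paired with methoxycarbonyl would read like compound 2 or like compound 3. Also open, on these data alone, is whether a carboxylic acid or a primary amide in place of the methyl ester would stay level with compound 3.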